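Vitamin D receptor agonists: amide variation on a shared core

The compounds below may be only part of what the source reports. "The series", "measured", "known", "first", "only" and "open" are said of these compounds alone.

Measured so far:
compound 1 `CCOC(=O)CN(C)C(=O)c1ccc(C(CC)(CC)c2ccc(OCC(=O)C(C)(C)C)c(C)c2)n1CC`: > 50000 nM
compound 2 `CC[C@@H](C)[C@H](NC(=O)c1ccc(C(CC)(CC)c2ccc(OCC(O)C(C)(C)C)c(C)c2)n1CC)C(=O)OC`: 26 nM

Within the data shown here, compound 2 gives the only numerical value in an assay on HL-60 cells for agonist activity at vitamin D3 receptor (Homo sapiens), read by microscopy, with a stated time of 96 h; on this read-out lower numbers stand for an effect already at smaller amounts and higher numbers for an effect only at larger amounts of compound. Compound 1 reaches only a limit in this assay, (the limit of > 50000 nM in this assay, at which 1 of the 2 values shown sits), not a number. Compound 3 `CCOC(=O)CN(C)C(=O)c1ccc(C(CC)(CC)c2ccc(OCC(O)C(C)(C)C)c(C)c2)n1CC` differs from compound 2 by ((ethoxycarbonyl)methyl)(methyl)amino in place of (1-(methoxycarbonyl)-2-methylbutyl)amino on a carbonyl carbon. Compound 3 thus carries the same ((ethoxycarbonyl)methyl)(methyl)amino group as compound 1, whose result is the limit > 50000 nM. Among the measured compounds shown here, no step between measured compounds exists to size this change, so expectation rests on that shared group. The step from compound 2 to compound 3 is expected to be a loss well beyond the scatter, a 77-fold higher number from compound 2 to compound 3 (1.89 log units; beyond the scatter). Compound 3 is estimated at 2000 nM, within 150 nM to 50000 nM.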

Compound 3, half-maximal effective concentration: 210 nM
Compound 3: the middle estimate sits 9.5-fold (0.98 log units) above what was measured; measured number inside the range.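

In this assay, ((ethoxycarbonyl)methyl)(methyl)amino in place of (1-(methoxycarbonyl)-2-methylbutyl)amino gives an 8.1-fold higher number from compound 2 to compound 3 (0.91 log units; beyond the scatter) and leaves a measurable value. With that amide group held constant, 1-hydroxy-2,2-dimethylpropyl in place of (tert-butyl)carbonyl gives an at least 230-fold lower number from compound 1 to compound 3 (2.37 log units; beyond the scatter) and so shows that the amide group alone does not set the result of compound 1. Compound 1 gives a limit, not a number: the limit of > 50000 nM in this assay, at which 1 of the 3 values shown sits.

The step to compound 3 changes the amide hydrogen and the chain together, so neither can be read alone. As far as these compounds go, how a carboxylic acid in place of the ester would read remains open.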